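Working notes: bromo for fluoro on a second core

A few compounds are considered here, and "the series" means these few. Any claim that something is new, unique, unknown or untested is made for them only; others in the source may bear on it.

In a functional assay on RAW264.7 cells (Mus musculus) for inhibition (on this read-out higher numbers stand for weaker inhibition and lower numbers for stronger inhibition), the measured members are:
compound 1 `O=C(NS(=O)(=O)c1ccc(F)cc1)c1ccncc1`, 9200 nM
compound 2 `O=C(NS(=O)(=O)c1ccc(Br)cc1)c1ccncc1`, 5500 nM
compound 3 `O=C(NS(=O)(=O)c1ccc(F)cc1)c1ccccn1`, 3300 nM

Two single changes connect these. The halogen exchange bromo in place of fluoro on an aromatic carbon gave a 1.7-fold lower number from compound 1 to compound 2 (0.22 log units; within the scatter). The cores differ as pyridin-2-yl in place of pyridin-4-yl on a carbonyl carbon, which gave a 2.8-fold lower number from compound 1 to compound 3 (0.45 log units; beyond the scatter). Compound 4 `O=C(NS(=O)(=O)c1ccc(Br)cc1)c1ccccn1` has not been measured; it carries the same change as compound 2 relative to compound 1, now on the core of compound 3, namely (bromo in place of fluoro on an aromatic carbon), and the surroundings of the place are the same in both pairs. For the measured compounds named here, for compound 4 the expected step is a 1.7-fold lower number from compound 3 to compound 4 (0.22 log units; within the scatter), the same size as the precedent, because a 1.7-fold lower number from compound 1 to compound 2 (0.22 log units; within the scatter) is the only guide available and sits within the scatter. Compound 4 is therefore estimated at 2000 nM, with a likely range from 900 nM to 4500 nM.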

Compound 4, half-maximal inhibitory concentration: 1900 nM
Estimate against measurement, compound 4: 1.1-fold (0.02 log units) above, within the range that was stated.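

In this assay the halogen exchange gave a 1.7-fold lower number from compound 3 to compound 4 (0.24 log units; within the scatter), matching its size on the first core: the same change on two cores in this assay, a 1.7-fold lower number (0.22 log units; within the scatter) from compound 1 to compound 2 and a 1.7-fold lower number (0.24 log units; within the scatter) from compound 3 to compound 4, 1.0-fold (0.02 log units) apart, within the scatter of two such steps. The core exchange gave a 2.9-fold lower number from compound 2 to compound 4 (0.46 log units; beyond the scatter), likewise matching its earlier size: the same change on two cores in this assay, a 2.8-fold lower number (0.45 log units; beyond the scatter) from compound 1 to compound 3 and a 2.9-fold lower number (0.46 log units; beyond the scatter) from compound 2 to compound 4, 1.0-fold (0.02 log units) apart, within the scatter of two such steps. Across these four compounds the two changes therefore carry over between cores without a detectable interaction, but the halogen steps lie within the scatter, so they do not establish a real effect of bromo on either core, and two cores cannot establish a general rule.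

As far as these compounds go, whether this agreement extends to chloro, methoxy or an amine in place of the halogen remains open. The compounds shown also leave open whether it holds on any further core.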